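Butylamino for 2-hydroxyethoxy on the carbonyl carbon

This account rests on a few compounds, and the source may have more. Where it says the series, first, only, none or still open, it means among the compounds named here.

Compound 1 `N#CCCCN(Cc1ccccc1)Cc1ccc2ccccc2c1` gives 0% in an assay on HEK293 cells for binding affinity to Substance-K receptor (Rattus norvegicus), read by FRET, tested at 10 uM; a higher number here means more inhibition at the concentration tested (going by the name of the read-out), a lower number less inhibition. Compound 2 `O=C(CN(Cc1ccccc1)Cc1ccc2ccccc2c1)OCCO` gives 0% in this assay, and the step of no change at the digits printed from compound 1 to compound 2 (within the scatter) shows that exchanging the 2-cyanoethyl for a (2-hydroxyethoxy)carbonyl on the saturated chain carbon bound to the amine nitrogen left the read-out where it was. Within the data shown here, compound 2 therefore stands level with compound 1, the only other measured member of the series, both at the bottom of the scale.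

Compound 3 `CCCCNC(=O)CN(Cc1ccccc1)Cc1ccc2ccccc2c1` differs from compound 2 at the carbonyl carbon whose other neighbour is a saturated chain carbon: butylamino in place of 2-hydroxyethoxy on a carbonyl carbon.

Among the measured compounds shown here, no measured step touches this position; the single step from compound 1 to compound 2 concerns the whole substituent on the amine nitrogen and was flat. Two very different groups there gave no inhibition, so the expectation for compound 3 is no step beyond the scatter, with a slight allowance upward: a number 2 percentage points higher from compound 2 to compound 3 (within the scatter). Compound 3 is estimated at 2%, within -8% to 15%.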

Compound 3, a percentage reported as inhibition, at one concentration (the size of the read-out at that concentration, not a potency): 0%
Compound 3: middle estimate off by 2 percentage points, on the high side; measured number inside the range.
By their numbers in this assay, from the lowest: compounds 1, 2 and 3 (each within the scatter of the next).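

In this assay, among these compounds, the exchange at the carbonyl carbon gives no change at the digits printed from compound 2 to compound 3 (within the scatter) and so adds the first reading for a change at this position: butylamino and 2-hydroxyethoxy cannot be told apart here. Read over the whole substituent, butylcarbamoyl in place of 2-cyanoethyl gives no change at the digits printed from compound 1 to compound 3 (within the scatter) and thus extends the flat result to a third group on the saturated chain carbon bound to the amine nitrogen. The series therefore gives no direction for changes at this position, and no independent data are available to explain the unchanged read-out.

Going by these compounds, it remains open whether a different group on the carbonyl carbon, such as a cyclohexylamino, a piperazine or a longer chain than butylamino, would move the read-out away from the level shared by these compounds. On these data alone, it is also open whether the groups compared here would separate on a different core, given that all three compounds share the same core and a single tested concentration.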